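The compounds below may be only part of what the source reports. "The series", "measured", "known", "first", "only" and "open" are said of these compounds alone.

Among three related compounds, compound 3 (`FC(F)(F)c1cccc(NC(=S)Nc2ccccc2)c1`) has the highest number in an ADME assay on Vero 76 cells (Chlorocebus sabaeus) for cytotoxicity, read by crystal violet staining, with a stated time of 96 h; a lower number here means that less compound is tolerated, a higher number that more compound is tolerated: compound 3 gives 39000 nM with hydrogen on the aromatic carbon in question. Compound 1 (`CC[C@H]1CC[C@H](c2ccc(NC(=S)Nc3cccc(C(F)(F)F)c3)cc2)CC1`) gives 10000 nM with 4-ethylcyclohexyl on that carbon, and compound 2 (`FC(F)(F)c1cccc(NC(=S)Nc2ccc(I)cc2)c1`) gives 9500 nM with iodo there. These two cannot be told apart, since the step of a 1.1-fold lower number from compound 1 to compound 2 (0.02 log units; within the scatter) is within the scatter.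

Compound 4 (`Fc1ccc(NC(=S)Nc2cccc(C(F)(F)F)c2)cc1`) has not yet been measured. It differs from compound 3 by one change (fluoro in place of hydrogen on an aromatic carbon): fluoro in place of hydrogen on an aromatic carbon, para to a large group.

For the measured compounds named here, two measured steps bear on this change, a 3.9-fold higher number from compound 1 to compound 3 (0.59 log units; beyond the scatter) and a 4.1-fold higher number from compound 2 to compound 3 (0.61 log units; beyond the scatter). Both are modest and beyond the scatter, and both show a hydrogen compound with a higher number than its substituted partner. Going by the values given here, that is only two comparisons, and neither involves fluoro, so the size of the new step is uncertain and it may stay within the scatter.

In this assay a smaller drop than those two is expected, with the estimated step (a 1.6-fold lower number from compound 3 to compound 4 (0.21 log units; within the scatter)) pointing to a lower number. For compound 4 the estimated value is 24000 nM within an expected range of 10000 nM to 50000 nM in this test.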

Compound 4, half-maximal cytotoxic concentration: 40000 nM
The estimate for compound 4 lay 1.7-fold (0.22 log units) below the measured number; the range from low to high includes it.
By their numbers in this assay, from the lowest: compounds 2 and 1 (each within the scatter of the next); then compounds 3 and 4 (each within the scatter of the next).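

In this assay, fluoro on this aromatic carbon, para to a large group, behaves like hydrogen, with a 1.0-fold higher number from compound 3 to compound 4 (0.01 log units; within the scatter) and so no real change. The earlier compounds shown here suggested that a substituent here goes with less compound being tolerated, but compound 4 goes against that pattern, which now holds only for iodo and 4-ethylcyclohexyl; fluoro stands clearly apart from both, with a 4.2-fold higher number from compound 2 to compound 4 (0.62 log units; beyond the scatter) and a 4.0-fold higher number from compound 1 to compound 4 (0.60 log units; beyond the scatter) in this same comparison. Nothing measured here explains why fluoro differs from these two groups.

As far as these compounds go, with only fluoro, iodo and 4-ethylcyclohexyl to compare with hydrogen at this carbon, it remains open where chloro, bromo, methyl or methoxy would fall, and whether an amine or a carboxylic acid here would leave the number unchanged or shift it in either direction. It also remains open whether the tolerance of fluoro is specific to this carbon, since the compounds shown carry no substituent on any other carbon of this ring and keep the trifluoromethyl group on the other ring throughout.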